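Tail amine exchange on compound 1

The compounds below may be only part of what the source reports. "The series", "measured", "known", "first", "only" and "open" are said of these compounds alone.

Among the compounds with values here, compound 1 `COc1cc2c(Oc3ccc(NC(=O)C4(c5nnc(-c6ccc(F)cc6)o5)CC4)cc3F)ccnc2cc1OCCCN1CCN(C)CC1` gives 1670 nM in a functional assay on PC-3 cells (Homo sapiens) for antiproliferative activity, read by MTT assay, with a stated time of 72 h (a lower number here means a stronger inhibitor, a higher number a weaker inhibitor), the only number in this small set. Compound 2 `COc1cc2nccc(Oc3ccc(NC(=O)c4nnc(-c5ccc(F)cc5)o4)cc3)c2cc1OC` returns only a limit, > 100000 nM, in this assay. That compound 2 sits at the limit of > 100000 nM in this assay, at which 1 of the 2 values shown sits, leaves compound 1 as the sole anchor for any projection. Compound 3 `COc1cc2c(Oc3ccc(NC(=O)C4(c5nnc(-c6ccc(F)cc6)o5)CC4)cc3F)ccnc2cc1OCCCN1CCCCC1` differs from compound 1 by piperidin-1-yl in place of 4-methylpiperazin-1-yl on a saturated chain carbon, three bonds along the chain from an oxygen on an aromatic ring. Within the data shown here, no measured step covers this change, so the step is expected to be small, a 1.3-fold lower number from compound 1 to compound 3 (0.11 log units; within the scatter), within scatter and without a settled direction. For compound 3 in this assay the estimated value is 1300 nM, between 450 nM and 4000 nM.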

Compound 3, half-maximal inhibitory concentration: 590 nM
Estimate against measurement, compound 3: 2.2-fold (0.34 log units) above; measured number inside the range.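

The tail amine on this chain is not a silent position in this assay: piperidin-1-yl in place of 4-methylpiperazin-1-yl gives a 2.8-fold lower number from compound 1 to compound 3 (0.45 log units; beyond the scatter). The exchange therefore keeps activity and moves the number in the favourable direction, though this rests on a single pair. Nothing shown accounts for the step.

Open: whether morpholin-4-yl or dimethylamino at the chain end would follow piperidin-1-yl or 4-methylpiperazin-1-yl, and whether a longer chain carrying piperidin-1-yl would shift the number further.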